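This account rests on a few compounds, and the source may have more. Where it says the series, first, only, none or still open, it means among the compounds named here.

Measured compounds in a functional assay on the whole organism (strain Wistar) for inhibition, with Rattus norvegicus as the target, read by paw edema, with stated times of 60 min and 3 h, at a dose of 100 mg/kg by the oral route; a higher number here means more inhibition at the dose given (going by the name of the read-out), a lower number less inhibition:
- Compound 1 `CCNC(=O)CC1CCc2cc(OC)c(OC)cc21` gives 26.1%
- Compound 2 `CCN(CC)C(=O)CC1CCc2cc(OC)c(OC)cc21` gives 37.7%
- Compound 3 `COc1cc2c(cc1OC)C(CC(=O)NC(C)C)CC2` gives 30.4%

All three share one core and differ only in the group on the amide nitrogen. On the numbers shown, compound 3 falls in the middle of the three: compound 1 is nearest to it and compound 2 furthest, yet both gaps lie within the scatter, so no real order among them can be read. Among the measured compounds shown here, the only step that reaches beyond the scatter is a number 11.6 percentage points higher from compound 1 to compound 2 (beyond the scatter), a modest gain. The steps that touch compound 3 directly, a number 4.3 percentage points higher from compound 1 to compound 3 (within the scatter) and a number 7.3 percentage points lower from compound 2 to compound 3 (within the scatter), are both within the scatter.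

Compound 4 `COc1cc2c(cc1OC)C(CC(=O)NCCO)CC2` is the next step from compound 3: 2-hydroxyethyl in place of isopropyl on an amide-type nitrogen. For the measured compounds named here, none of the measured steps brings a hydroxyl group onto this chain, so no step in this assay bears on it closely. Since even larger swaps at this nitrogen moved the number little, a change of no more than the scatter is expected, giving a number 0.4 percentage points lower from compound 3 to compound 4 (within the scatter). Compound 4 is therefore estimated at 30%, within 15% to 45%.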

Compound 4, a percentage reported as inhibition, in the whole organism at one dose (the size of the read-out at that dose, not a potency): 12.3%
Estimate against measurement, compound 4: 17.7 percentage points above, and the stated range ends above it.
By their numbers in this assay, from the lowest: compound 4; then compounds 1, 3 and 2 (each within the scatter of the next, the first and the last beyond it).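

In this assay, among the compounds shown here, the ethyl, diethyl and isopropyl amides gave no step downward beyond the scatter, but 2-hydroxyethyl on the amide-type nitrogen gives a number 18.1 percentage points lower from compound 3 to compound 4 (beyond the scatter). The other comparisons agree, with a number 25.4 percentage points lower from compound 2 to compound 4 (beyond the scatter) and a number 13.8 percentage points lower from compound 1 to compound 4 (beyond the scatter), the last of these being hydroxy in place of hydrogen on the chain, so compound 4 stands lowest of the series and this position is sensitive to a hydroxyl on the chain in a way the earlier swaps did not show. Nothing available explains this fall.

Open, from the compounds shown here alone, is whether the hydroxyl itself matters or only its place on the chain, which a 2-methoxyethyl group or a longer 3-hydroxypropyl chain would address. A 2-aminoethyl group on the same nitrogen would show whether the fall extends beyond the hydroxyl.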